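The compounds below may be only part of what the source reports. "The series", "measured", "known", "first", "only" and "open" are said of these compounds alone.

In a functional assay on DU-145 cells (Homo sapiens) for antiproliferative activity, read by propidium iodide staining, with a stated time of 96 h (a lower number here means a stronger inhibitor, a higher number a weaker inhibitor), compound 1 (`CC(O)(CSc1ccc(S(F)(F)(F)(F)F)cc1)C(=O)Nc1ccc(S(F)(F)(F)(F)F)cc1`) gives 22300 nM and compound 2 (`CC(O)(COc1ccc(S(F)(F)(F)(F)F)cc1)C(=O)Nc1cccc(S(F)(F)(F)(F)F)c1`) gives 12800 nM as its half-maximal inhibitory concentration. Compound 2 therefore stands level with compound 1, since the two numbers lie within the usual scatter of each other. Compound 3 (`CC(O)(COc1ccc(OC(F)(F)F)cc1)C(=O)Nc1cccc(S(F)(F)(F)(F)F)c1`) keeps the core of compound 2 and alters one group, on an aromatic carbon para to a large group: a group of 5 heavy atoms (1 carbon, 1 oxygen, 3 fluorine; no ring) in place of a group of 6 heavy atoms (5 fluorine, 1 sulfur; no ring), on an aromatic carbon describes the exchange, with trifluoromethoxy entering. Within the data shown here, no measured pair shows this exchange on its own, so the expectation is loose. In this assay no change beyond the scatter is expected, with at most a slight drift towards a higher number, and the estimated move is a 1.3-fold higher number from compound 2 to compound 3 (0.10 log units; within the scatter) on that reading. For compound 3 the expected value is 16000 nM within an estimated range of 6500 nM to 40000 nM in this measurement.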

Compound 3, half-maximal inhibitory concentration: 19100 nM
The estimate for compound 3 lay 1.2-fold (0.08 log units) below the measured number, within the range that was stated.
By their numbers in this assay, from the lowest: compounds 2, 3 and 1 (each within the scatter of the next).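

In this assay, placing trifluoromethoxy on the aromatic carbon para to a large group, where the group of 6 heavy atoms (5 fluorine, 1 sulfur) stood, gives a 1.5-fold higher number from compound 2 to compound 3 (0.17 log units; within the scatter). Among these compounds, this is the first reading of a single exchange here, as the two earlier compounds differ in more than one place, and it shows that this position tolerates the swap without a change beyond the scatter in this assay. Nothing available bears on why the two groups read alike here.

On these data alone, whether an amine or a carboxylic acid on this same aromatic carbon would move the number beyond the scatter remains open. Also open, as far as these compounds go, is whether the same exchange elsewhere on the shared core, or on the core of compound 1, would read the same way.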